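Removing the acetyl group from compound 2

The source may report more compounds than this note shows. Statements on the series, on what has been measured and on what is new or still open speak of the compounds shown alone.

Measured so far in a toxicity assay on KB cells (Homo sapiens) for cytotoxicity, read by fluorescence, with a stated time of 3 days; a lower number here means that less compound is needed, a higher number that more compound is needed for the effect:
- compound 1 `CCCCOC(=O)CNC(=O)[C@H](CSc1ccc([N+](=O)[O-])cc1[N+](=O)[O-])NC(=O)CC[C@H](NC(=O)OC)C(=O)OCCCC`: > 300 uM
- compound 2 `CCCCOC(=O)CNC(=O)[C@H](CSc1ccc([N+](=O)[O-])cc1[N+](=O)[O-])NC(=O)CC[C@H](NC(C)=O)C(=O)OCCCC`: > 300 uM
- compound 3 `CCCCCCCCCCCCCC(=O)N[C@@H](CCC(=O)N[C@@H](CSc1ccc([N+](=O)[O-])cc1[N+](=O)[O-])C(=O)NCC(=O)OCCCC)C(=O)OCCCC`: > 300 uM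

All three entries are limits of the assay and not numbers. Compound 2 stands at > 300 uM, which is a limit, so it has no measured place within the series. The series as a whole sits at one point: the limit of > 300 uM in this assay, at which 3 of the 3 values shown sit.

Compound 4 `CCCCOC(=O)CNC(=O)[C@H](CSc1ccc([N+](=O)[O-])cc1[N+](=O)[O-])NC(=O)CC[C@H](N)C(=O)OCCCC` differs from compound 2 at one place: hydrogen in place of acetyl on an amine nitrogen. In words, this is hydrogen in place of acetyl on an amine nitrogen.

Among the measured compounds shown here, two measured steps bear on this change, since both alter the group on that amine nitrogen: a step that the two limits leave unreadable from compound 1 to compound 2 and a step that the two limits leave unreadable from compound 2 to compound 3. Neither has a readable size, so neither sets the size of the next step. All three measured compounds carry a carbonyl group on that nitrogen, and compound 4 does not, so the change leads outside the measured set. A move towards a lower number in this assay is expected only tentatively, and another limit remains quite possible.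

The expected step is an at least 2.0-fold lower number from compound 2 to compound 4 (0.30 log units; that floor lies within the scatter). The estimate for compound 4 is 150 uM, with an expected range from 30 uM to 450 uM.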

Compound 4, concentration for half-maximal effect: 107 uM
Compound 4: the middle estimate sits 1.4-fold (0.15 log units) above what was measured, and the stated range covers the measured number.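

In this assay, among the compounds shown here, hydrogen in place of acetyl on this amine nitrogen gives the first readable change at this position: an at least 2.8-fold lower number from compound 2 to compound 4 (0.44 log units; beyond the scatter). Hydrogen in place of methoxycarbonyl at the same nitrogen gives an at least 2.8-fold lower number from compound 1 to compound 4 (0.44 log units; beyond the scatter), and both steps start from a limit of the assay, so each gives a floor and not a full size. The steps among the three compounds with a carbonyl group on this nitrogen cannot be read, and compound 4, which has no carbonyl group there, is the only compound shown that stands off the limit: the limit of > 300 uM in this assay, at which 3 of the 4 values shown sit.

From the compounds shown here alone, it remains open whether hydrogen itself matters or whether a methylamino or dimethylamino group, which also has no carbonyl group on this nitrogen, would likewise leave the limit in this assay. Also open, going by these compounds, is how far the value of compound 4 depends on the rest of the amino(butoxycarbonyl)methyl unit, for example with a carboxylic acid in place of the butoxycarbonyl group.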